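Swapping a chlorothiophene for benzyl on the sulfonyl sulfur

The compounds below may be only part of what the source reports. "The series", "measured", "known", "first", "only" and "open" are said of these compounds alone.

Compound 1 `CC1OC(=O)c2cc(C#N)c(N3CC(C(=O)NS(=O)(=O)Cc4ccccc4)C3)nc21` gives > 300000 nM, a limit
Compound 2 `N#Cc1cc2c(nc1N1CC(C(=O)NS(=O)(=O)c3ccc(Cl)s3)C1)COC2=O` gives 193000 nM, a number

Among the measured compounds shown here, in a functional assay (Platelet, plasma) for inhibition, with Homo sapiens as the target (a higher number here means a weaker inhibitor, a lower number a stronger inhibitor), compound 2 gives 193000 nM, the only actual number so far, so it cannot yet be ranked against a second number. The other result is a limit: compound 1 reads > 300000 nM and no number.

Compound 3 `N#Cc1cc2c(nc1N1CC(C(=O)NS(=O)(=O)Cc3ccccc3)C1)COC2=O` has not been measured. It differs from compound 2 in one place, with benzyl in place of 5-chlorothiophen-2-yl on a sulfonyl sulfur and the rest of the structure unchanged.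

For the measured compounds named here, no measured pair shows what this swap does on its own. Compound 1 also carries benzyl on its sulfonyl sulfur, and its reading of > 300000 nM is a limit, which tilts the expectation towards the weak side. A small move towards weaker inhibition is therefore expected in this assay, probably no larger than the scatter, and a reading that is only a limit would be no surprise. The expected change is a 1.2-fold higher number from compound 2 to compound 3 (0.08 log units; within the scatter), and this estimate is loose. For compound 3 the estimated value is 230000 nM, with an expected range from 80000 nM to 600000 nM.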

Compound 3, half-maximal inhibitory concentration: > 300000 nM
Compound 3 gave a limit, no number (the forecaster's own chance of this, stated with the estimate: 45%); middle value at least 1.3-fold (0.11 log units) away from the limit.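

In this assay, among the compounds shown here, compounds 2 and 3 form the first pair that differs only on a sulfonyl sulfur whose other neighbour is an amide-type nitrogen, and the change gives an at least 1.5-fold higher number from compound 2 to compound 3 (0.19 log units; that floor lies within the scatter). This shows that benzyl in place of 5-chlorothiophen-2-yl brings no gain in inhibition here, but the step is only a floor and that floor lies within the scatter, so neither a real loss nor its size is established. The step from compound 1 to compound 3, with hydrogen in place of methyl on a saturated ring carbon, cannot be read, since both of its ends are limits: the limit of > 300000 nM in this assay, at which 2 of the 3 values shown sit.

Still open, going by these compounds, is whether the chlorine or the thiophene ring accounts for compound 2 giving a number, a question that plain thiophen-2-yl on the same sulfur would address. Also open, on these data alone, is whether a carboxylic acid or an amine on a longer chain at this sulfur would give a reading clearly stronger than that of compound 2.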